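Chloro in Place of Trifluoromethoxy: Little Change Expected

This account rests on a few compounds, and the source may have more. Where it says the series, first, only, none or still open, it means among the compounds named here.

Measured compounds:
compound 1 `FC(F)(F)Oc1ccc(-c2cc(COc3ccccc3-c3nc4ccccc4s3)on2)cc1`: 26600 nM
compound 2 `Fc1ccc(-n2cc(COc3ccccc3-c3nc4ccccc4s3)nn2)cc1`: 26200 nM

In a functional assay on MCF7 cells (Homo sapiens) for cytotoxicity, read by MTT assay, with a stated time of 24 h (on this read-out higher numbers stand for weaker inhibition and lower numbers for stronger inhibition), compound 1 gives 26600 nM, and compound 2 gives 26200 nM, a number within the scatter of compound 1, so the two stand together. Compound 3 `Clc1ccc(-c2cc(COc3ccccc3-c3nc4ccccc4s3)on2)cc1` differs from compound 1 by chloro in place of trifluoromethoxy on an aromatic carbon. Going by the values given here, no measured pair covers this change, so the expectation rests on the two values alone. Compound 3 is expected to give 25000 nM, with a range from 8000 nM to 80000 nM. The expected step of a 1.1-fold lower number from compound 1 to compound 3 (0.03 log units; within the scatter) stays within the scatter, in no clear direction.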

Compound 3, half-maximal inhibitory concentration: 23800 nM
The estimate for compound 3 lay 1.1-fold (0.02 log units) above the measured number, within the range that was stated.
By their numbers in this assay, from the lowest: compounds 3, 2 and 1 (each within the scatter of the next).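

In this assay, going by these compounds alone, chloro in place of trifluoromethoxy gives a 1.1-fold lower number from compound 1 to compound 3 (0.05 log units; within the scatter) and this is the first direct reading of a change at this position. A single chlorine atom can stand where a group of five heavy atoms stood, on the same aromatic carbon, with the number staying within the scatter. No measurement at hand bears on this result.

From the compounds shown here alone, whether an amine or a carboxylic acid on this carbon would shift the number remains open. So does whether the same change would read alike on the core of compound 2.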